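Para-trifluoromethoxy sulfone with meta-pentafluorosulfanyl anilide

The source may hold more compounds than are shown below. What is called first, only, known or untested is meant among the compounds shown, and "the series" means these compounds.

The series shares a tertiary alcohol bearing a methyl group, a sulfonylmethyl arm and an anilide, and differs in the aryl group on the sulfonyl sulfur and in where the pentafluorosulfanyl group sits on the anilide ring. Compound 1 `CC(O)(CS(=O)(=O)c1ccccc1C(F)(F)F)C(=O)Nc1ccc(S(F)(F)(F)(F)F)cc1` gives in a functional assay on DU-145 cells (Homo sapiens) for antiproliferative activity, read by propidium iodide staining, with a stated time of 96 h (a higher number here means a weaker inhibitor, a lower number a stronger inhibitor), a value of 29400 nM. Compound 2 `CC(O)(CS(=O)(=O)c1ccc(OC(F)(F)F)cc1)C(=O)Nc1ccc(S(F)(F)(F)(F)F)cc1` gives in this assay a value of 39300 nM. The change from compound 1 to compound 2 is 4-(trifluoromethoxy)phenyl in place of 2-(trifluoromethyl)phenyl on a sulfonyl sulfur, and it made a step of a 1.3-fold higher number from compound 1 to compound 2 (0.13 log units; within the scatter). Compound 3 `CC(O)(CS(=O)(=O)c1ccccc1C(F)(F)F)C(=O)Nc1cccc(S(F)(F)(F)(F)F)c1` gives in this assay a value of 27300 nM; the difference between the core of compound 3 and the core of compound 1 is not broken down here. The values of compound 3 and compound 1 lie within the scatter of each other, as do those of compound 3 and compound 2.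

Compound 4 `CC(O)(CS(=O)(=O)c1ccc(OC(F)(F)F)cc1)C(=O)Nc1cccc(S(F)(F)(F)(F)F)c1` is not yet measured. It differs from compound 3 by 4-(trifluoromethoxy)phenyl in place of 2-(trifluoromethyl)phenyl on a sulfonyl sulfur, the same change as from compound 1 to compound 2, made at the same place. Because the earlier step was a 1.3-fold higher number from compound 1 to compound 2 (0.13 log units; within the scatter), the step from compound 3 to compound 4 is expected to be about a 1.3-fold higher number from compound 3 to compound 4 (0.12 log units; within the scatter) in this assay. Compound 4 is therefore estimated to give in this assay a value of 36000 nM, with a range from 18000 nM to 72000 nM.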

Compound 4, half-maximal inhibitory concentration: 35600 nM
Compound 4: the middle estimate sits 1.0-fold (0.00 log units) above what was measured; measured number inside the range.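

On the core of compound 3, 4-(trifluoromethoxy)phenyl in place of 2-(trifluoromethyl)phenyl on a sulfonyl sulfur gives in this assay a step of a 1.3-fold higher number from compound 3 to compound 4 (0.12 log units; within the scatter), so this step cannot be told apart from repeat-measurement noise. Set beside the earlier step, the change reads the same on both cores: the same change on two cores in this assay, a 1.3-fold higher number (0.13 log units; within the scatter) from compound 1 to compound 2 and a 1.3-fold higher number (0.12 log units; within the scatter) from compound 3 to compound 4, 1.0-fold (0.01 log units) apart, within the scatter of two such steps. This shows that, across these two cores and in this one assay, the change carries over without a detectable difference, but the agreement is between two steps that both lie within the scatter, so it does not show that the swap itself alters the read-out, nor does it show that a larger step would transfer in the same way or that the result extends to any other core.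

The compounds shown keep the sulfonyl aryl group to a phenyl ring bearing trifluoromethyl or trifluoromethoxy and the anilide ring to pentafluorosulfanyl, so it remains open whether a sulfonyl aryl group carrying an amine or a carboxylic acid, or an anilide bearing a nitrile in place of pentafluorosulfanyl, would give a step beyond the scatter. Also open, as far as these compounds go, is whether a step of that kind would hold from one core to the other as this one does.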